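The compounds below may be only part of what the source reports. "The series", "measured", "known", "first", "only" and "open" are said of these compounds alone.

Values so far in an ADME assay on MDCK cells (Canis lupus familiaris) for cytotoxicity, with a stated time of 48 h; on this read-out lower numbers stand for higher toxicity in this test and higher numbers for lower toxicity in this test:
Compound 1 `CCC(CC)O[C@@H]1C=C(C(=O)NOC)C[C@H](NC(=N)N)[C@H]1NC(C)=O` gives > 100000 nM
Compound 2 `CCC(CC)O[C@@H]1C=C(C(=O)NOCCCc2cc3ccccc3[nH]2)C[C@H](NC(=N)N)[C@H]1NC(C)=O` gives > 100000 nM

Compound 1 sits at > 100000 nM in this assay and this is a limit of the assay, not a number. Compound 2 gives > 100000 nM and this too is only a limit. Compound 3 `CCC(CC)O[C@@H]1C=C(C(=O)NS(C)(=O)=O)C[C@H](NC(=N)N)[C@H]1NC(C)=O` carries methylsulfonyl in place of methoxy on an amide-type nitrogen. Among the compounds with values here, the one measured change, 2-(1H-indol-2-yl)ethyl in place of hydrogen on a saturated chain carbon bound to an oxygen, is a different one and leaves a step that the two limits leave unreadable from compound 1 to compound 2 as its only trace. Within the data shown here, with compound 1 and compound 2 both resting on the limit of > 100000 nM in this assay, at which 2 of the 2 values shown sit, as the only guide, a number no higher from compound 1 to compound 3 (the limit leaves the size open) is expected to stay within the scatter, with no direction foreseen. For compound 3 the estimate is 100000 nM with an expected range from 50000 nM to 300000 nM and a reading at the limit is the likeliest outcome.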

Compound 3, half-maximal cytotoxic concentration: > 100000 nM
Compound 3: only a limit was reported; the forecaster's own chance of this, stated with the estimate: 90%; the middle value sits exactly at the limit.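

In this assay compound 3 gives > 100000 nM, which is a limit of the assay and not a number. No step can be read from compound 1 to compound 3, as the values of compound 1, compound 2 and compound 3 all rest on one limit: the limit of > 100000 nM in this assay, at which 3 of the 3 values shown sit. The compounds shown leave open at what concentration, if any, toxicity appears for any of them.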